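The source may report more compounds than this note shows. Statements on the series, on what has been measured and on what is new or still open speak of the compounds shown alone.

Three compounds share one core. Compound 1 `CC(C)(N)C(=O)N[C@H](COCc1ccccc1)c1nnnn1CCCCCNS(C)(=O)=O` carries a chain that ends in a methanesulfonamide, compound 2 `CC(C)(N)C(=O)N[C@H](COCc1ccccc1)c1nnn(CCCc2ccccc2NS(C)(=O)=O)n1` carries an aromatic ring bearing the same group, and compound 3 `CC(C)(N)C(=O)N[C@H](COCc1ccccc1)c1nnn(CCCCC#N)n1` ends its chain in a nitrile. All three were tested in an assay on isolated protein for displacement of a labelled ligand from growth hormone secretagogue receptor type 1 (Homo sapiens), with a stated time of 1 h; on this read-out lower numbers stand for stronger inhibition and higher numbers for weaker inhibition. Compound 1 gives > 5000 nM, which is a limit of the assay and not a number. Compound 3 likewise returns only a limit, > 5000 nM. Compound 2 gives 2390 nM. For the measured compounds named here, the single measured step between compounds that differ in one place is an at least 2.0-fold higher number from compound 2 to compound 3 (0.32 log units; beyond the scatter), so the chain bearing an aromatic ring gave the lower number. Compound 1 thus sits at the limit of > 5000 nM in this assay, at which 2 of the 3 values shown sit, and its true position is not known beyond that.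

Compound 4 `CC(C)(N)C(=O)N[C@H](COCc1ccccc1)c1nnnn1CCC(=O)NCc1ccccc1` has not been measured. It differs from compound 1 by benzylcarbamoyl in place of 3-(methanesulfonamido)propyl on a saturated chain carbon, two bonds along the chain from an aromatic nitrogen. The step that bears on it is the one just described, an at least 2.0-fold higher number from compound 2 to compound 3 (0.32 log units; beyond the scatter), which links the presence of an aromatic ring on the chain to a lower number; here a ring enters while the methanesulfonamide leaves, so a modest step down is expected, an at least 1.2-fold lower number from compound 1 to compound 4 (0.09 log units; that floor lies within the scatter), though with the start point only a limit. Compound 4 is estimated at 4000 nM, ranging from 1200 nM to 15000 nM.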

Compound 4, inhibition constant: 1070 nM
Compound 4: the middle estimate sits 3.7-fold (0.57 log units) above what was measured; the measured number lies below the stated range.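

In this assay, benzylcarbamoyl in place of 3-(methanesulfonamido)propyl, on a saturated chain carbon, two bonds along the chain from an aromatic nitrogen, gives an at least 4.6-fold lower number from compound 1 to compound 4 (0.66 log units; beyond the scatter), so a change at this position can move the number beyond the scatter. For the compounds shown here, until now the only readable step was the one between a chain bearing an aromatic ring and a nitrile chain; this second step also favours the compound with a ring on its chain, and neither step goes against that pattern, though both rest on a limit at one end. Going by these compounds, the true size of the new step therefore remains unknown, and compound 1 stays at a limit and not a number: the limit of > 5000 nM in this assay, at which 2 of the 4 values shown sit.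

On these data alone, it remains open whether the step follows the aromatic ring or the carbonyl and amide hydrogen of benzylcarbamoyl, for these enter together while the methanesulfonamide leaves. Also open, as far as these compounds go, is how this assay would read a fluorine on the benzyl ring, a pyridine in place of the benzene ring, or a longer chain between the carbonyl and the ring.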